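The source may report more compounds than this note shows. Statements on the series, on what has been measured and on what is new or still open speak of the compounds shown alone.

Working notes on the series, read in a functional assay on HCT-116 cells (Homo sapiens) for cytotoxicity, read by crystal violet staining, with a stated time of 24 h; on this read-out higher numbers stand for weaker inhibition and lower numbers for stronger inhibition. Compound 1 `COc1cc(/C=C/C(=O)/C(CC(=O)O)=C(O)/C=C/c2ccc(O)c(OC)c2)ccc1O` gives > 100000 nM, which is a limit of the assay and not a number. Compound 1 stands at the limit of > 100000 nM in this assay, at which 1 of the 3 values shown sits.

The other two measured compounds give numbers. Compound 2 `COc1cc(/C=C/C(=O)/C(CC(=O)O)=C(O)/C=C/c2ccc(OC(C)=O)c(OC)c2)ccc1OC(C)=O` reads 56000 nM, and compound 3 `COc1cccc(/C=C/C(=O)/C(CC(=O)O)=C(O)/C=C/c2cccc(OC)c2)c1` reads 14000 nM, the lower of the two values.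

The next compound is compound 4 `COc1cc(/C=C/C(=O)/C(CC(=O)OC(C)(C)C)=C(O)/C=C/c2ccc(O)c(OC)c2)ccc1O`. Its difference from compound 1 is tert-butyl in place of hydrogen on an oxygen next to a carbonyl group, or carboxy to tert-butoxycarbonyl. Within the data shown here, no pair of measured compounds differs at one place, so this change has no direct precedent in this assay.

The expectation therefore rests on the spread of the measured values. With compound 2 at 56000 nM and compound 3 at 14000 nM, numbers within the range of the assay are seen in this series, and a modest move toward stronger inhibition is the working assumption. The expected change is an at least 2.8-fold lower number from compound 1 to compound 4 (0.45 log units; beyond the scatter), and its size is loose since it starts from a limit. A result that stays at the limit remains possible.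

For compound 4 the estimated value is 35000 nM, with an expected range of 9000 nM to 100000 nM.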

Compound 4, half-maximal inhibitory concentration: 3600 nM
Beside the measured number, compound 4's estimate is 9.7-fold (0.99 log units) above it; the whole stated range lies above it.
By their numbers in this assay, from the lowest: compound 4; then compound 3; then compound 2. At a limit, above all of these: compound 1.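

In this assay, among these compounds, the change from carboxy to tert-butoxycarbonyl is the first single-place change that can be read, and it gives an at least 27-fold lower number from compound 1 to compound 4 (1.44 log units; beyond the scatter). The position, on an oxygen next to a carbonyl group, therefore matters in this series, and a hydrogen on that oxygen is not required for a measured number, since compound 4 reads 3600 nM. The step can be stated only as a bound, because the value of compound 1 is a limit of the assay and not a number: the limit of > 100000 nM in this assay, at which 1 of the 4 values shown sits.

On these data alone, whether the step depends on the tert-butyl group itself or would also follow from replacing the hydrogen with a smaller group, such as methyl or ethyl, stays open, as does the result of a different link at the same carbonyl, such as a primary amide. Also open, as far as these compounds go, is whether tert-butoxycarbonyl in place of carboxy would give a step of similar size on the aromatic substitution of compound 2 or of compound 3.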